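The compounds below may be only part of what the source reports. "The series", "measured", "known", "first", "only" and "open" are said of these compounds alone.

Measured in a functional assay for inhibition, with Oryctolagus cuniculus as the target; on this read-out higher numbers stand for weaker inhibition and lower numbers for stronger inhibition:
- compound 1 `O=C(O)CCCCCCCNS(=O)(=O)c1ccccc1`: 700 nM
- compound 2 `O=C(O)CCCCCCCCNS(=O)(=O)c1ccccc1`: 400 nM
- compound 3 `O=C(O)CCCCCCCCCCNS(=O)(=O)c1ccccc1`: 10000 nM

Compound 3 has the highest number of the three, and its steps to both others lie beyond the scatter. The unmeasured compound 4 `O=C(O)CCCCCCCCCCCNS(=O)(=O)c1ccccc1` differs from it by carboxymethyl in place of carboxy on a saturated chain carbon, ten or more bonds along the chain from a sulfonamide nitrogen. The same exchange, seven bonds along the chain from a sulfonamide nitrogen, gave a 1.8-fold lower number from compound 1 to compound 2 (0.24 log units; within the scatter), which is within the scatter. Larger extensions gave bigger changes: 3-carboxypropyl in place of carboxy gave a 14-fold higher number from compound 1 to compound 3 (1.15 log units; beyond the scatter), and 2-carboxyethyl in place of carboxy gave a 25-fold higher number from compound 2 to compound 3 (1.40 log units; beyond the scatter). Among the compounds with values here, no measured compound has a chain longer than that of compound 3, so the evidence is thin. A modest further rise, smaller than those large steps, is expected in this assay, namely a 2.0-fold higher number from compound 3 to compound 4 (0.30 log units; within the scatter). For compound 4 the estimated value is 20000 nM, with an expected range of 7000 nM to 60000 nM.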

Compound 4, half-maximal inhibitory concentration: > 10000 nM
Compound 4 ended at the assay's limit; the forecaster's own chance of this, stated with the estimate: 25%; the middle value does not contradict the limit.
By their numbers in this assay, from the lowest: compounds 2 and 1 (each within the scatter of the next); then compound 3.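

In this assay, the value of compound 4, > 10000 nM, is a limit and not a number. The last extension of the chain therefore gives only a number no lower from compound 3 to compound 4 (the limit leaves the size open), and its size cannot be read. Against the shorter chains the result is clear, with an at least 25-fold higher number from compound 2 to compound 4 (1.39 log units; beyond the scatter) and an at least 14-fold higher number from compound 1 to compound 4 (1.15 log units; beyond the scatter), and carboxymethyl in place of carboxy on compound 3 does not bring back the lower numbers of those two compounds. Whether this exchange behaves differently here than in the step that gave a 1.8-fold lower number from compound 1 to compound 2 (0.24 log units; within the scatter) cannot be decided: the same change on two cores in this assay, a 1.8-fold lower number (0.24 log units; within the scatter) from compound 1 to compound 2 and a number no lower (the limit leaves the size open) from compound 3 to compound 4; the limit leaves it open whether they differ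

The compounds shown leave open how far compound 4 lies past the limit, and where between the chains of compound 2 and compound 3 the rise sets in. They also leave open whether an amide or a hydroxamic acid in place of the carboxylic acid would change the picture on the longer chains.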